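The source may report more compounds than this note shows. Statements on the series, on what has been measured and on what is new or still open speak of the compounds shown alone.

Compound 1 `N#Cc1cc(-c2nc(C(c3ccc(F)cc3)c3ccc(F)cc3)sc2CC(=O)O)ccc1F`: 520 nM
Compound 2 `O=C(O)Cc1sc(C(c2ccc(F)cc2)c2ccc(F)cc2)nc1-c1ccnc(F)c1`: 4.7 nM
Compound 3 `COc1cc(-c2nc(C(c3ccc(F)cc3)c3ccc(F)cc3)sc2CC(=O)O)ccn1`: 380 nM

The three compounds share one core and differ only in the aromatic group attached to it. In an in vitro functional assay on HEK285-7 cells for antagonist activity at prostaglandin D2 receptor 2 (Homo sapiens), read by BRET and beta-arrestin recruitment (on this read-out higher numbers stand for weaker inhibition and lower numbers for stronger inhibition), compound 1 gives the highest number of the three; compound 3 sits within the scatter of it, a 1.4-fold lower number from compound 1 to compound 3 (0.14 log units; within the scatter), whereas compound 2 lies far below it, a 110-fold lower number from compound 1 to compound 2 (2.04 log units; beyond the scatter). Among the compounds with values here, compound 4 `NS(=O)(=O)c1ccc(-c2nc(C(c3ccc(F)cc3)c3ccc(F)cc3)sc2CC(=O)O)cc1` has not yet been measured. 4-sulfamoylphenyl in place of 3-cyano-4-fluorophenyl on an aromatic carbon Both earlier exchanges of this group bear on the step: one was large and one within the scatter, and no measured compound carries a sulfamoyl group. Compound 4 is therefore expected to show a 2.1-fold lower number from compound 1 to compound 4 (0.32 log units; beyond the scatter) in this assay, with wide uncertainty. The estimated value of compound 4 is 250 nM, between 40 nM and 1500 nM.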

Compound 4, half-maximal inhibitory concentration: > 100000 nM
Compound 4 gave a limit, no number (the forecaster's own chance of this, stated with the estimate: 5%); middle value at least 400-fold (2.60 log units) away from the limit.
By their numbers in this assay, from the lowest: compound 2; then compounds 3 and 1 (each within the scatter of the next). At a limit, above all of these: compound 4.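

At this position, on the aromatic carbon next to the ring nitrogen, the earlier exchanges had lowered the number or stayed within the scatter, whereas 4-sulfamoylphenyl raises it sharply, with an at least 190-fold higher number from compound 1 to compound 4 (2.28 log units; beyond the scatter), an at least 260-fold higher number from compound 3 to compound 4 (2.42 log units; beyond the scatter) and an at least 21000-fold higher number from compound 2 to compound 4 (4.32 log units; beyond the scatter). Compound 4 gives a limit, not a number: the limit of > 100000 nM in this assay, at which 1 of the 4 values shown sits.

Compounds 1 and 4 both carry a six-membered aromatic ring of carbon only here, yet only compound 1 gives a number, so that ring alone does not settle the read-out.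

From the compounds shown here alone, how far beyond the limit compound 4 lies stays open. Also open, going by these compounds, is how a plain phenyl or a 4-methylsulfonylphenyl group would read at this position, which bears on whether the step follows the sulfonyl group or its amine nitrogen.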